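The source may hold more compounds than are shown below. What is called first, only, known or untested is meant among the compounds shown, and "the series" means these compounds.

Among the compounds with values here, in a functional assay on MDA-MB-231 cells (Homo sapiens) for cytotoxicity, read by MTT assay, with a stated time of 24 h (on this read-out lower numbers stand for stronger inhibition and higher numbers for weaker inhibition), compound 1 (`COc1ccc2c(c1)cc(-c1cc(OC)c(OC)c(OC)c1)n2Cc1ccc(O)cc1`) gives 17300 nM as the only actual number so far. Compound 2 (`COc1ccc2c(c1)c(Cc1ccc(O)cc1)c(-c1cc(OC)c(OC)c(OC)c1)n2Cc1ccc(O)cc1`) reports > 30000 nM and this is a limit of the assay, not a number. The step of an at least 1.7-fold higher number from compound 1 to compound 2 (0.23 log units; that floor lies within the scatter) is all that can be said about that pair, and it falls on an aromatic carbon, not on the oxygen that changes next. Compound 3 (`COc1ccc2c(c1)cc(-c1cc(OC)c(OC)c(OC)c1)n2Cc1ccc(OC(C)CN(C)C)cc1`) keeps the core of compound 1 and differs by 1-((dimethylamino)methyl)ethyl in place of hydrogen on an oxygen on an aromatic ring in one place: hydroxy becomes 1-((dimethylamino)methyl)ethoxy. Within the data shown here, no measured step touches this oxygen, so no step clearly beyond the scatter is expected in this assay and no direction can be argued from the data. The expected size is a 1.7-fold lower number from compound 1 to compound 3 (0.24 log units; within the scatter) and it remains uncertain. Compound 3 is estimated at 10000 nM with an expected range from 3000 nM to 30000 nM on this reasoning.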

Compound 3, half-maximal inhibitory concentration: 10600 nM
Estimate against measurement, compound 3: 1.1-fold (0.03 log units) below; measured number inside the range.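

In this assay, the hydrogen on the oxygen of the aromatic ring gives way to 1-((dimethylamino)methyl)ethyl, and the step reads a 1.6-fold lower number from compound 1 to compound 3 (0.21 log units; within the scatter). This is the only step shown at this oxygen, and it shows that the free hydroxy of compound 1 can be replaced by this much larger branched chain with no change that stands clear of the usual scatter between repeated measurements. Nothing in the data at hand bears on why the two numbers stay so close.

The compounds shown leave open whether a smaller group on this oxygen, such as a plain methyl, would give the same picture. They also leave open how a longer chain, a morpholine in place of the dimethylamino group or a carboxylic acid at the chain end would read.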